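Para-substituent on the benzyl group: bromo to hydrogen

The compounds below may be only part of what the source reports. "The series", "measured", "known", "first", "only" and "open" are said of these compounds alone.

Compound 2 `CCN(Cc1ccc(Br)cc1)Cc1nn(-c2ccccc2F)c2c1CCS(=O)(=O)O2` sits at the top of the two values in hand: in a functional assay, with a stated time of 2 h, tested at 100 uM (on this read-out lower numbers stand for less inhibition and higher numbers for more inhibition at the one concentration tested (going by the name of the read-out)), compound 2 gives 12.9%. Within the data shown here, its only neighbour is compound 1 `CCN(Cc1ccc(F)cc1)Cc1nn(-c2ccccc2F)c2c1CCS(=O)(=O)O2`, which in this assay gives 0.6%; the step of a number 12.3 percentage points higher from compound 1 to compound 2 (beyond the scatter) came with bromo in place of fluoro on an aromatic carbon, so within this pair the larger halogen goes with the higher reading.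

Compound 3 `CCN(Cc1ccccc1)Cc1nn(-c2ccccc2F)c2c1CCS(=O)(=O)O2` is not yet measured. It differs from compound 2 by hydrogen in place of bromo on an aromatic carbon.

Among the measured compounds shown here, no measured step removes the halogen outright; the one step that bears on this position, a number 12.3 percentage points higher from compound 1 to compound 2 (beyond the scatter), shows that a smaller substituent at that carbon gave the lower reading. The expectation is therefore that compound 3 falls back to the level of compound 1 or thereabouts, with a number 9.9 percentage points lower from compound 2 to compound 3 (within the scatter) going downward. For compound 3 the estimated value in this assay is 3%, within a range from -6% to 13%.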

Compound 3, a percentage reported as inhibition, at one concentration (the size of the read-out at that concentration, not a potency): 1.8%
Compound 3: the middle estimate sits 1.2 percentage points above what was measured, and the stated range covers the measured number.
By their numbers in this assay, from the lowest: compounds 1 and 3 (each within the scatter of the next); then compound 2.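

The bromo is what separates compound 2 from compound 3 in this assay (a number 11.1 percentage points lower from compound 2 to compound 3 (beyond the scatter)), so the higher reading of compound 2 now stands against an unsubstituted phenyl as well as against the fluoro analogue. Hydrogen and fluoro at this aromatic carbon are not told apart (a number 1.2 percentage points higher from compound 1 to compound 3 (within the scatter)), which means the series so far shows no general halogen trend: fluoro goes against any such reading, and only bromo stands out. No measurement on hand accounts for what bromo does here.

As far as these compounds go, whether chloro, iodo, methyl or methoxy at this carbon would read with bromo or with hydrogen remains open. From the compounds shown here alone, all three readings come from a single concentration and give no potency, so how far the bromo step carries beyond this one read-out also remains open.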